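Cytotoxicity notes: substituent changes on the aniline nitrogen

The source may hold more compounds than are shown below. What is called first, only, known or untested is meant among the compounds shown, and "the series" means these compounds.

Measured so far in an ADME assay on A549 cells (Homo sapiens) for cytotoxicity, read by resazurin assay, with a stated time of 48 h; a lower number here means that less compound is tolerated, a higher number that more compound is tolerated:
compound 1 `CCCCCCC(C)Nc1ccc(NC(=O)c2cc(Cl)ccc2O)c(Cl)c1` gives 23500 nM
compound 2 `CC1(Nc2ccc(NC(=O)c3cc(Cl)ccc3O)c(Cl)c2)CCCC1` gives 157000 nM
compound 3 `CC1(ON(c2ccc(NC(=O)c3cc(Cl)ccc3O)c(Cl)c2)C2(C)CCCC2)CCCC1` gives 18000 nM

Compound 2 stands highest of the three numbers, so it is the most tolerated of the set; both other compounds sit well below it, each beyond the scatter. The two measured steps both touch the nitrogen on the aromatic ring: a 6.7-fold higher number from compound 1 to compound 2 (0.82 log units; beyond the scatter) and an 8.7-fold lower number from compound 2 to compound 3 (0.94 log units; beyond the scatter). Each is modest but clearly beyond the scatter, so what sits on this nitrogen moves the read-out.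

Compound 4 `O=C(Nc1ccc(NCc2ccncc2)cc1Cl)c1cc(Cl)ccc1O` is the next variant at the same site: (pyridin-4-yl)methyl in place of 1-methylcyclopentyl on a nitrogen on an aromatic ring. Going by the values given here, only the step from compound 1 to compound 2 bears directly on an exchange of the carbon group on this nitrogen, and it was sizeable. Since compound 2 is already the highest number and the other two substitutions at this nitrogen both gave lower numbers, the expected direction for compound 4 is downward, by a modest amount beyond the scatter, namely a 5.2-fold lower number from compound 2 to compound 4 (0.72 log units; beyond the scatter). The estimate for compound 4 in this assay is therefore 30000 nM, expected to fall between 8000 nM and 120000 nM.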

Compound 4, half-maximal cytotoxic concentration: 65300 nM
Beside the measured number, compound 4's estimate is 2.2-fold (0.34 log units) below it; low and high end bracket the measured number.
By their numbers in this assay, from the lowest: compounds 3 and 1 (each within the scatter of the next); then compound 4; then compound 2.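

In this assay the (pyridin-4-yl)methyl group, with its six-membered aromatic ring holding 1 hetero atom, gives a 2.4-fold lower number from compound 2 to compound 4 (0.38 log units; beyond the scatter) and a 2.8-fold higher number from compound 1 to compound 4 (0.44 log units; beyond the scatter) when set against the open chain. This shows that a group on this nitrogen with a hydrogen-bond acceptor can sit inside the range of the two carbon-only groups, ranking below 1-methylcyclopentyl and above 1-methylheptyl, with both steps beyond the scatter. Nothing at hand explains this order.

The compounds shown leave open whether the pyridine ring nitrogen matters at all, which a benzyl group on this nitrogen would help to separate from the effect of the ring itself. A (pyridin-3-yl)methyl group would show whether the place of that ring nitrogen counts.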